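The source may hold more compounds than are shown below. What is called first, only, known or untested is meant among the compounds shown, and "the series" means these compounds.

Compound 2 `FC(F)(F)c1ccc(Nc2cc3[nH]c(-c4cccc(C(F)(F)F)c4)nc3cn2)nc1` gives 90% in an ADME assay on microsomes from liver (Homo sapiens) for metabolic stability, read by LC-MS, with a stated time of 30 min, tested at 0.1 uM (on this read-out higher numbers stand for a more stable compound and lower numbers for a less stable compound), the higher of the two numbers measured, yet the gap to compound 1 `FC(F)(F)c1cccc(-c2nc3cnc(Nc4cccnn4)cc3[nH]2)c1` with 84% is within the scatter, as the step of a number 6 percentage points higher from compound 1 to compound 2 (within the scatter) shows. Compound 3 `FC(F)(F)c1ccc(Nc2cc3[nH]c(CC4CC4)nc3cn2)nc1` differs from compound 2 by cyclopropylmethyl in place of 3-(trifluoromethyl)phenyl on an aromatic carbon. Among the compounds with values here, the single measured step changed a different part of the molecule, so no measured step bears on this change, and the outcome is uncertain. For compound 3 a step of a number 15 percentage points lower from compound 2 to compound 3 (beyond the scatter) is expected. Compound 3 is therefore estimated at 75%, within a range from 50% to 95%.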

Compound 3, percent of the compound remaining: 84%
Estimate against measurement, compound 3: 9 percentage points below; the measured number falls inside the stated range.
By their numbers in this assay, from the lowest: compounds 1, 3 and 2 (each within the scatter of the next).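

The step of a number 6 percentage points lower from compound 2 to compound 3 (within the scatter) came with cyclopropylmethyl in place of 3-(trifluoromethyl)phenyl on the aromatic carbon between two ring nitrogen atoms. This position therefore took a three-membered non-aromatic ring in place of a six-membered aromatic ring, and the read-out did not move beyond the scatter. Nothing available explains this outcome.

As far as these compounds go, whether an amine, a carboxylic acid or a longer chain at this carbon would hold up in this assay stays open. So does whether cyclopropylmethyl behaves alike with pyridazin-3-yl on the nitrogen.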